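The compounds below may be only part of what the source reports. "The series", "measured", "known", "first", "only" and "open" are said of these compounds alone.

For the measured compounds named here, in a functional assay on DU-145 cells (Homo sapiens) for inhibition, read by trypan blue exclusion, with a stated time of 72 h (on this read-out higher numbers stand for weaker inhibition and lower numbers for stronger inhibition), compound 1 (`Cn1c(=O)c(S(=O)(=O)c2ccc(F)cc2)cc2cnc(Nc3ccc4occc4c3)nc21`) gives 5000 nM, the lower of the two numbers measured so far. Going by the values given here, the only other measured compound, compound 2 (`Cn1c(=O)c(S(=O)(=O)c2ccc(F)cc2F)cc2cnc(Nc3ccc4occc4c3)nc21`), gives 15000 nM. The comparison is a 3.0-fold higher number from compound 1 to compound 2 (0.48 log units; beyond the scatter), a modest step beyond the scatter, and it comes with fluoro in place of hydrogen on an aromatic carbon. The next compound, compound 3 (`Cn1c(=O)c(S(=O)(=O)c2ccc(F)cc2)cc2cnc(Nc3ccc4[nH]ncc4c3)nc21`), leaves that part of compound 1 alone and changes a different one: 1H-indazol-5-yl in place of 1-benzofuran-5-yl on a nitrogen on an aromatic ring. In words, 1H-indazol-5-yl stands in place of 1-benzofuran-5-yl on a nitrogen on an aromatic ring. Among the compounds with values here, no measured step covers this exchange, so the fluoro step offers a gauge of size only and gives no direction. A modest step is expected in this assay, judged from a 3.0-fold higher number from compound 1 to compound 2 (0.48 log units; beyond the scatter) seen there, and a result within the scatter of compound 1 would be no surprise. The estimated change is a 1.7-fold lower number from compound 1 to compound 3 (0.22 log units; within the scatter), a slight lean towards a lower number that the data do not establish. For compound 3 the estimated value is 3000 nM, with an expected range from 600 nM to 15000 nM.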

Compound 3, half-maximal inhibitory concentration: 5000 nM
Compound 3: the middle estimate sits 1.7-fold (0.22 log units) below what was measured; the measured number falls inside the stated range.
By their numbers in this assay, from the lowest: compounds 1 and 3 (each within the scatter of the next); then compound 2.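

In this assay the exchange of 1-benzofuran-5-yl for 1H-indazol-5-yl on a nitrogen on an aromatic ring gives no change at the digits printed from compound 1 to compound 3 (within the scatter), so at this place a five-membered aromatic ring with 2 hetero atoms and a hydrogen-bond donor serves in the read-out as well as the ring it replaces. For the compounds shown here, until now the only comparison was a 3.0-fold higher number from compound 1 to compound 2 (0.48 log units; beyond the scatter), which concerned fluoro on an aromatic carbon and said nothing about this nitrogen substituent, so this is the first sign that the read-out can stay level through a change here. Nothing available explains why the number holds across this exchange.

As far as these compounds go, compounds 2 and 3 differ in two places, so it remains open whether the added fluoro would bring the same step on the 1H-indazol-5-yl compound. Also open, from the compounds shown here alone, is how the number would respond at this nitrogen to a plain phenyl group, to a phenyl ring carrying a piperazine or a carboxylic acid, or to a saturated ring such as cyclohexyl.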